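This account rests on a few compounds, and the source may have more. Where it says the series, first, only, none or still open, it means among the compounds named here.

Measured compounds in a functional assay on MIA PaCa-2 cells (Homo sapiens) for inhibition, read by MTT assay, with a stated time of 3 days; a lower number here means a stronger inhibitor, a higher number a weaker inhibitor:
Compound 1, `CCN(CC)S(=O)(=O)c1ccc(S(=O)(=O)N2CCC[C@@H](C(=O)NC3CCOCC3)C2)cc1`, gives > 10000 nM, which is a limit of the assay.
Compound 2, `CCN(CC)S(=O)(=O)c1ccc(S(=O)(=O)N2CCC[C@@H](C(=O)N[C@H]3CCOC3)C2)cc1`, gives > 10000 nM, also a limit.
Compound 3, `CCN(CC)S(=O)(=O)c1ccc(S(=O)(=O)N2CCC[C@@H](C(=O)N3CCC(C(F)(F)F)CC3)C2)cc1`, gives > 10000 nM, again a limit.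

Compound 3 therefore stands at the limit of > 10000 nM in this assay, at which 3 of the 3 values shown sit, with no number to place it against the others. Compound 4, `CCN(CC)S(=O)(=O)c1ccc(S(=O)(=O)N2CCC[C@@H](C(=O)N3CCS(=O)(=O)CC3)C2)cc1`, differs from it by 1,1-dioxothiomorpholin-4-yl in place of 4-(trifluoromethyl)piperidin-1-yl on a carbonyl carbon. The measured steps that touch this position, a step that the two limits leave unreadable from compound 1 to compound 3 and a step that the two limits leave unreadable from compound 2 to compound 3, are both unreadable, so no size or direction can be drawn from them for the change to compound 4. Compound 4 is accordingly expected to sit near the same limit, at an estimated 15000 nM, with a range from 5000 nM to 50000 nM. The step this estimate implies is a step that the limit leaves unreadable from compound 3 to compound 4, expected to be none beyond the scatter.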

Compound 4, half-maximal inhibitory concentration: > 10000 nM
Compound 4 ended at the assay's limit (the forecaster's own chance of this, stated with the estimate: 85%); the middle value lies beyond the limit too.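

Compound 4 gives no readable step against compound 1, compound 2 or compound 3, as all four rest at one limit: the limit of > 10000 nM in this assay, at which 4 of the 4 values shown sit.
The compounds shown leave open whether any group on the carbonyl carbon would give a measurable value.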